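Swapping the Amide Side Chain for a Triol

This account rests on a few compounds, and the source may have more. Where it says the series, first, only, none or still open, it means among the compounds named here.

Measured so far in an assay on HEK293 cells for displacement of a labelled ligand from adenosine receptor A2b (Homo sapiens), read by scintillation counting, with a stated time of 30 min, tested at 10 uM; on this read-out higher numbers stand for more inhibition at the one concentration tested (going by the name of the read-out) and lower numbers for less inhibition:
compound 1, `COCCNC(=O)c1cc2cccc(OC)c2oc1=N`, 43%
compound 2, `COc1cccc2cc(C(=O)Nc3c(C#N)ncn3-c3ccc(F)cc3)c(=N)oc12`, 30%
compound 3, `COc1cc(Br)cc2cc(C(=O)NCCCO)c(=N)oc12`, 30%

All three compounds share the same core and were tested in this assay. Compound 1 stands highest of the three, with 43%. Compound 2 and compound 3 each sit lower by a gap that goes beyond the usual scatter of this kind of measurement, so compound 1 is the clearest binder of the set so far.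

Compound 4, `COc1cccc2cc(C(=O)NC(CO)(CO)CO)c(=N)oc12`, has not yet been measured. It differs from compound 1 in one place: 2-hydroxy-1,1-bis(hydroxymethyl)ethyl in place of 2-methoxyethyl on an amide-type nitrogen. Among the compounds with values here, no two measured compounds differ at just this place, so there is no measured step to show how large a change here might be. The nearest hint is compound 3, whose side chain on the amide-type nitrogen ends in a hydroxyl and which gives 30%, lower than compound 1. On that basis a moderate drop in this assay is expected, though with wide uncertainty. Compound 4 is expected to give 30%, within a range from 12% to 48%. This expectation amounts to an estimated step of a number 13 percentage points lower from compound 1 to compound 4 (beyond the scatter).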

Compound 4, a percentage reported as inhibition, at one concentration (the size of the read-out at that concentration, not a potency): 28%
Beside the measured number, compound 4's estimate is 2 percentage points above it; measured number inside the range.
By their numbers in this assay, from the lowest: compounds 4, 2 and 3 (each within the scatter of the next); then compound 1.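

In this assay, within the data shown here, putting 2-hydroxy-1,1-bis(hydroxymethyl)ethyl in place of 2-methoxyethyl on the amide-type nitrogen gives a number 15 percentage points lower from compound 1 to compound 4 (beyond the scatter) as the first measured step at this place. The change does not remove the read-out, since compound 4 still gives 28% at the one concentration tested, so some inhibition survives this much larger side chain. The change raises the heavy atoms, oxygens and hydrogen-bond donors together, and nothing shown gives a cause for the step or ties it to any one of these.

From the compounds shown here alone, whether the step follows the added hydroxyl groups or the greater size of the chain stays open. A 2-hydroxyethyl chain or a plain tert-butyl group on the same nitrogen, with the rest of compound 1 unchanged, would help separate the two.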